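Diethylsulfamoyl to cyclopropylsulfonyl on compound 1

The compounds below may be only part of what the source reports. "The series", "measured", "known", "first", "only" and "open" are said of these compounds alone.

Compound 1 `CCN(CC)S(=O)(=O)c1ccc(S(=O)(=O)N2CCC[C@@H](C(=O)N3CCC(F)(F)CC3)C2)cc1` carries a 4,4-difluoropiperidin-1-yl group on the carbonyl carbon and a diethylsulfamoyl group on the aryl ring. Going by the values given here, in a functional assay on MIA PaCa-2 cells (Homo sapiens) for inhibition, read by MTT assay, with a stated time of 7 days (on this read-out lower numbers stand for stronger inhibition and higher numbers for weaker inhibition), compound 1 gives 16 nM, the lowest of the three numbers so far. Compound 2 `CCN(CC)S(=O)(=O)c1ccc(S(=O)(=O)N2CCC[C@@H](C(=O)N3CCC(O)CC3)C2)cc1` gives 870 nM and compound 3 `CCN(CC)S(=O)(=O)c1ccc(S(=O)(=O)N2CCC[C@@H](C(=O)N3CCC(OC)CC3)C2)cc1` gives 140 nM; the steps read a 54-fold higher number from compound 1 to compound 2 (1.74 log units; beyond the scatter) and an 8.8-fold higher number from compound 1 to compound 3 (0.94 log units; beyond the scatter), with a 6.2-fold lower number from compound 2 to compound 3 (0.79 log units; beyond the scatter) separating the two variants.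

Compound 4 `O=C([C@@H]1CCCN(S(=O)(=O)c2ccc(S(=O)(=O)C3CC3)cc2)C1)N1CCC(F)(F)CC1` differs from compound 1 in one place: cyclopropyl in place of diethylamino on a sulfonyl sulfur. All three measured steps concern the group on the carbonyl carbon; none changes anything at the sulfonyl sulfur. The measured pairs therefore give no direct reading on the size or direction of this change, and the piperidine amide that made compound 1 the lowest number is kept. On that basis the working expectation for compound 4 is a number close to that of compound 1, with a step of a 1.9-fold higher number from compound 1 to compound 4 (0.27 log units; within the scatter) expected in this assay. Compound 4 is thus estimated at 30 nM, within 8 nM to 120 nM.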

Compound 4, half-maximal inhibitory concentration: 26 nM
Beside the measured number, compound 4's estimate is 1.2-fold (0.06 log units) above it, and the stated range covers the measured number.
By their numbers in this assay, from the lowest: compounds 1 and 4 (each within the scatter of the next); then compound 3; then compound 2.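

Going by these compounds alone, the sulfonyl sulfur gives the first reading outside the group on the carbonyl carbon: in this assay cyclopropyl in place of diethylamino gives a 1.6-fold higher number from compound 1 to compound 4 (0.21 log units; within the scatter) and leaves the two compounds inseparable on this read-out. With the 4,4-difluoropiperidin-1-yl amide held fixed, the diethylamino group is therefore not required for a low number here, unlike the 4,4-difluoropiperidin-1-yl group, whose replacement gives an 8.8-fold higher number from compound 1 to compound 3 (0.94 log units; beyond the scatter) in this assay at the carbonyl carbon. No measurement at hand says why the two sulfur substituents read alike.

Only one replacement at this sulfur is shown, so whether a methyl, phenyl or morpholin-4-yl group there would read the same stays open. Also open, from the compounds shown here alone, is whether the cyclopropylsulfonyl result carries over to the 4-methoxypiperidin-1-yl amide.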